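Swapping the phenyl of compound 3 for a larger benzyl group

A few compounds are considered here, and "the series" means these few. Any claim that something is new, unique, unknown or untested is made for them only; others in the source may bear on it.

Measured compounds:
- compound 1, `c1ccc(-c2ccc3c(NCCCNCc4ccco4)ccnc3c2)cc1`: 32000 nM
- compound 2, `COc1cccc(CNCCCNc2ccnc3cc(-c4ccccc4)ccc23)c1O`: 32000 nM
- compound 3, `COc1ccc(F)cc1CNCCCNc1ccnc2cc(-c3ccccc3)ccc12`: 32000 nM

All three measured compounds share one core and differ only in the aromatic group at the end of the amine-bearing chain. In a physicochemical assay for solubility, with a stated time of 18 h, at pH 7.4 (on this read-out higher numbers stand for higher solubility and lower numbers for lower solubility), compound 1 gives 32000 nM, compound 2 gives 32000 nM and compound 3 gives 32000 nM. The steps among them, no change at the digits printed from compound 1 to compound 2 (within the scatter), no change at the digits printed from compound 1 to compound 3 (within the scatter) and no change at the digits printed from compound 2 to compound 3 (within the scatter), show that changing the group on that chain carbon left the result where it was. Compound 3 therefore stands level with compounds 1 and 2.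

Compound 4, `COc1ccc(F)cc1CNCCCNc1ccnc2cc(Cc3cccc(C(F)(F)F)c3)ccc12`, changes a different part of the molecule: 3-(trifluoromethyl)benzyl in place of phenyl on an aromatic carbon. Going by the values given here, none of the measured steps touches this aromatic carbon of the core, so no step bears directly on the change; the only guidance is that compound 3 sits at 32000 nM and that the entering group carries more heavy atoms than the leaving phenyl. A modest downward step is expected, a 1.8-fold lower number from compound 3 to compound 4 (0.25 log units; within the scatter), possibly no larger than the scatter. Compound 4 is estimated at 18000 nM, with a range from 5000 nM to 35000 nM.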

Compound 4, solubility: 4200 nM
For compound 4 the middle estimate is 4.3-fold (0.63 log units) above the measured one; the measured number lies below the stated range.
By their numbers in this assay, from the lowest: compound 4; then compounds 1, 2 and 3 (each within the scatter of the next).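

Among the earlier compounds, changing the aromatic group at the end of the amine-bearing chain left the number in this assay unmoved, so they said nothing about the rest of the molecule. Going by these compounds alone, this aromatic carbon of the shared core behaves differently: putting 3-(trifluoromethyl)benzyl in place of phenyl gives a 7.6-fold lower number from compound 3 to compound 4 (0.88 log units; beyond the scatter), the first step in this set that lies beyond the scatter. The entering group has more heavy atoms and includes fluorine, while both groups have one six-membered aromatic ring and no hydrogen-bond donors or acceptors, but no measurement available here explains the drop.

With a single change at this carbon, the effects of the added carbon link and the trifluoromethyl group cannot be separated, and a plain benzyl group, or a phenyl carrying trifluoromethyl directly, would be the comparison that could pull them apart. Also open, as far as these compounds go, are whether an amine or a carboxylic acid on this carbon would move the number the other way, and whether the same change would have a similar effect with the chain ends of compound 1 and compound 2.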